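This account rests on a few compounds, and the source may have more. Where it says the series, first, only, none or still open, it means among the compounds named here.

Measured so far in a functional assay on DLD-1 cells (Homo sapiens) for antiproliferative activity, read by CellTiter-Glo, with a stated time of 72 h; a higher number here means a weaker inhibitor, a lower number a stronger inhibitor: compound 1 `Cc1cc(C)c(S(=O)(=O)N2CCC(N3CCC(C)CC3)CC2)c(C)c1` gives 0.03 nM; compound 3 `Cc1cc(C)c(S(=O)(=O)N2CCC(N3CCC(Cc4ccccc4)CC3)CC2)c(C)c1` gives 3.5 nM. Compound 2 `Cc1cc(C)c(S(=O)(=O)N2CCC(N3CCC(CCC#N)CC3)CC2)c(C)c1` gives > 5000 nM, which is a limit of the assay rather than a number.

Compound 1 stands with the lowest number of the two given, and compound 3 is nearest, at a 120-fold higher number from compound 1 to compound 3 (2.07 log units; beyond the scatter). Compound 4 `Cc1cc(C)c(S(=O)(=O)N2CCC(N3CCC(C)OC3)CC2)c(C)c1` differs from compound 1 by a group of 7 heavy atoms (5 carbon, 1 nitrogen, 1 oxygen; one six-membered non-aromatic ring with 2 hetero atoms) in place of a group of 7 heavy atoms (6 carbon, 1 nitrogen; one six-membered non-aromatic ring with 1 hetero atom), on a saturated ring carbon. For the measured compounds named here, no measured step makes this same change. Going by the values given here, the steps that exist, an at least 160000-fold higher number from compound 1 to compound 2 (5.22 log units; beyond the scatter) and an at least 1400-fold lower number from compound 2 to compound 3 (3.15 log units; beyond the scatter), concern a group on a saturated chain carbon instead, and show only that changes to this part of compound 1 move the number greatly. A rise of moderate size is therefore expected in this assay, estimated as a 100-fold higher number from compound 1 to compound 4 (2.00 log units; beyond the scatter). Compound 4 is expected to give 3 nM, in the range 0.1 nM to 100 nM.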

Compound 4, half-maximal inhibitory concentration: 92 nM
Beside the measured number, compound 4's estimate is 31-fold (1.49 log units) below it; the measured number falls inside the stated range.
By their numbers in this assay, from the lowest: compound 1; then compound 3; then compound 4. At a limit, above all of these: compound 2.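

In this assay, for the compounds shown here, the earlier steps all added atoms to the methyl group of compound 1, whereas this one keeps the count of 7 heavy atoms and exchanges one ring carbon for oxygen. Even so, the number moves strongly, with a 3100-fold higher number from compound 1 to compound 4 (3.49 log units; beyond the scatter), so at this position a change in ring composition alone can cost much activity. Nothing measured here explains the size of this step. The compounds shown leave open whether a morpholin-4-yl or a 4-methylpiperazin-1-yl group in the same place would behave like compound 4 or compound 1.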